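Changing the sulfonyl ring: from pyridine to dimethylpyrazole

The compounds below may be only part of what the source reports. "The series", "measured", "known", "first", "only" and "open" are said of these compounds alone.

- Compound 1 `CCn1c([C@@H](C)NS(=O)(=O)c2cccc(Cl)c2)nc2ccc(C(F)(F)F)cc21`: > 100 mL.min-1.g-1
- Compound 2 `CCn1c([C@@H](C)NS(=O)(=O)c2c(F)cc(F)cc2F)nc2ccc(C(F)(F)F)cc21`: 19 mL.min-1.g-1
- Compound 3 `CCn1c([C@@H](C)NS(=O)(=O)c2ccccn2)nc2ccc(C(F)(F)F)cc21`: < 3 mL.min-1.g-1

These values come from an ADME assay (liver) for metabolic stability, with Liver microsome (Homo sapiens) as the target, read by LC-MS, using microsomes and NADPH, with a stated time of 5 min, at 37 degrees C; a lower number here means slower removal, a higher number faster removal of the compound. For compound 1, > 100 mL.min-1.g-1 is a limit of the assay and not a number. For compound 3, < 3 mL.min-1.g-1 is also a limit, and it lies at the low end of the values shown.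

Compound 4 `CCn1c([C@@H](C)NS(=O)(=O)c2cn(C)nc2C)nc2ccc(C(F)(F)F)cc21` has not been measured. It carries 1,3-dimethyl-1H-pyrazol-4-yl in place of pyridin-2-yl on a sulfonyl sulfur.

Three measured steps change this same place, and all lie beyond the scatter: an at least 5.2-fold lower number from compound 1 to compound 2 (0.72 log units; beyond the scatter), an at least 6.3-fold lower number from compound 2 to compound 3 (0.80 log units; beyond the scatter) and an at least 33-fold lower number from compound 1 to compound 3 (1.52 log units; beyond the scatter). None of them involves the incoming group, so they show only that this place matters. Compound 4, like compound 3, has an aromatic ring with hetero atoms, and that kind of swap gave an at least 6.3-fold lower number from compound 2 to compound 3 (0.80 log units; beyond the scatter). A low number therefore seems likely, though probably not as low as the limit.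

The expected change is an at least 2.0-fold higher number from compound 3 to compound 4 (0.30 log units; that floor lies within the scatter), a modest rise. For compound 4, the estimated value is 6 mL.min-1.g-1, with an expected range of 3 mL.min-1.g-1 to 20 mL.min-1.g-1.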

Compound 4, intrinsic clearance in microsomes: 28 mL.min-1.g-1
Compound 4: middle estimate off by 4.7-fold (0.67 log units), on the low side; the measured number lies above the stated range.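

Hetero atoms in the aromatic ring on the sulfonyl sulfur do not by themselves keep the number low in this assay: the 1,3-dimethyl-1H-pyrazol-4-yl ring gives an at least 9.3-fold higher number from compound 3 to compound 4 (0.97 log units; beyond the scatter). This ring cannot be told apart from the all-carbon 2,4,6-trifluorophenyl ring, with a 1.5-fold higher number from compound 2 to compound 4 (0.17 log units; within the scatter), yet it still differs from the 3-chlorophenyl ring, with an at least 3.5-fold lower number from compound 1 to compound 4 (0.55 log units; beyond the scatter). The steps that involve compound 3 and compound 1 are floors only: each of these two compounds stands at a limit of the assay.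

The compounds shown do not separate the effect of ring size from that of the methyl groups on the pyrazole, which an unsubstituted pyrazol-4-yl ring would address. On these data alone, whether the low number of compound 3 needs the pyridin-2-yl ring specifically, or would also appear with a pyridin-3-yl ring, stays open.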